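The compounds below may be only part of what the source reports. "The series", "measured", "known", "first", "only" and "open" are said of these compounds alone.

Measured compounds:
compound 1 `O=C1O[C@H]([C@@H](O)Cn2cc(-c3ccc(Br)cc3)nn2)C(OCc2ccccc2)=C1OCc1ccccc1`, in a functional assay on MCF7 cells (Homo sapiens) for antiproliferative activity, read by MTT assay, with a stated time of 72 h (on this read-out lower numbers stand for stronger inhibition and higher numbers for weaker inhibition), compound 1 gives 5620 nM
compound 2 `CC(C)(C)c1cn(C[C@H](O)[C@H]2OC(=O)C(OCc3ccccc3)=C2OCc2ccccc2)nn1`, in this assay compound 2 gives 730 nM

Compound 1 stands highest of the two numbers shown; its nearest neighbour is compound 2, reached by a 7.7-fold lower number from compound 1 to compound 2 (0.89 log units; beyond the scatter). The unmeasured compound 3 `O=C1O[C@H]([C@@H](O)Cn2ccnn2)C(OCc2ccccc2)=C1OCc1ccccc1` differs from compound 1 as follows: hydrogen in place of 4-bromophenyl on an aromatic carbon. Among the compounds with values here, no measured step removes a group on that aromatic carbon altogether, so the only step that bears on it is the one from compound 1 to compound 2, in which exchanging one group for another on the same carbon moved the number beyond the scatter. Whether the bare hydrogen behaves more like the 4-bromophenyl of compound 1 or shifts the number further is therefore open. The expected step of a 1.4-fold higher number from compound 1 to compound 3 (0.15 log units; within the scatter) is small and uncertain. Compound 3 is estimated to give 8000 nM in this assay, within 2000 nM to 30000 nM.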

Compound 3, half-maximal inhibitory concentration: > 100000 nM
Compound 3 gave a limit, no number (the forecaster's own chance of this, stated with the estimate: 15%); middle value at least 12-fold (1.09 log units) away from the limit.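

In this assay compound 3 gives a limit and not a number: the limit of > 100000 nM in this assay, at which 1 of the 3 values shown sits. Within the data shown here, the earlier compounds showed only that one group on this aromatic carbon could be exchanged for another, with a 7.7-fold lower number from compound 1 to compound 2 (0.89 log units; beyond the scatter) and a measurable number on both sides. Leaving hydrogen on that carbon goes much further, with an at least 17-fold higher number from compound 1 to compound 3 (1.25 log units; beyond the scatter) and an at least 130-fold higher number from compound 2 to compound 3 (2.13 log units; beyond the scatter), so among these three compounds, those carrying 4-bromophenyl or tert-butyl there give a number and the one carrying hydrogen does not.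

The compounds shown leave open how a small group such as methyl, or an amine or a hydroxymethyl group, would read on that carbon, and how an unsubstituted phenyl would compare with 4-bromophenyl. From the compounds shown here alone, the full size of both new steps also stays open, since compound 3 has no number.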